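From tert-butyl to 2-(1H-indol-3-yl)ethyl on the carbonyl carbon

The source may report more compounds than this note shows. Statements on the series, on what has been measured and on what is new or still open speak of the compounds shown alone.

In a toxicity assay on KB cells (Homo sapiens) for cytotoxicity, read by fluorescence, with a stated time of 3 days (on this read-out lower numbers stand for an effect already at smaller amounts and higher numbers for an effect only at larger amounts of compound), compound 1 (`CCCCOC(=O)CNC(=O)[C@H](CSc1ccc([N+](=O)[O-])cc1[N+](=O)[O-])NC(=O)CC[C@H](NC(=O)CC(C)C)C(=O)OCCCC`) gives 59.6 uM and compound 2 (`CCCCOC(=O)CNC(=O)[C@H](CSc1ccc([N+](=O)[O-])cc1[N+](=O)[O-])NC(=O)CC[C@H](NC(=O)C(C)(C)C)C(=O)OCCCC`) gives 83.4 uM. Within the data shown here, compound 2 therefore stands within the scatter of compound 1, its only measured neighbour.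

The next structure is compound 3 (`CCCCOC(=O)CNC(=O)[C@H](CSc1ccc([N+](=O)[O-])cc1[N+](=O)[O-])NC(=O)CC[C@H](NC(=O)CCc1c[nH]c2ccccc12)C(=O)OCCCC`), which keeps the shared core and changes one group: 2-(1H-indol-3-yl)ethyl in place of tert-butyl on a carbonyl carbon. In words, 2-(1H-indol-3-yl)ethyl sits in place of tert-butyl on a carbonyl carbon.

Among the measured compounds shown here, only one measured step bears on this change, tert-butyl in place of isobutyl at that same carbonyl carbon: a 1.4-fold higher number from compound 1 to compound 2 (0.15 log units; within the scatter). That step stayed within the scatter, but it exchanged one open chain for another. For the measured compounds named here, no compound with a ring in this place has been measured, so the guide is weak and the range must stay wide on both sides.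

In this assay, the expected change is a 1.5-fold lower number from compound 2 to compound 3 (0.18 log units; within the scatter), so no clear step beyond the scatter is expected. The estimate for compound 3 is 55 uM, with an expected range of 22 uM to 120 uM.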

Compound 3, concentration for half-maximal effect: 26 uM
The estimate for compound 3 lay 2.1-fold (0.33 log units) above the measured number; low and high end bracket the measured number.
By their numbers in this assay, from the lowest: compound 3; then compounds 1 and 2 (each within the scatter of the next).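

In this assay the group on the carbonyl carbon bound to the amide-type nitrogen can move the read-out beyond the scatter: 2-(1H-indol-3-yl)ethyl in place of tert-butyl gives a 3.2-fold lower number from compound 2 to compound 3 (0.51 log units; beyond the scatter) and, read as (1H-indol-3-yl)methyl in place of isopropyl on the saturated chain carbon, the change from the other open chain gives a 2.3-fold lower number from compound 1 to compound 3 (0.36 log units; beyond the scatter) as well, both modest in size. Among these compounds, the two open chains lie within the scatter of each other, so the first step beyond the scatter at this place comes with the entry of a five-membered aromatic ring with a hetero atom and a six-membered aromatic ring of carbon only, together with a hydrogen-bond donor. Nothing at hand accounts for this shift.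

The added size, the rings and the donor enter together in compound 3, so the step cannot yet be assigned to any one of them. A 2-phenylethyl group would keep a six-membered aromatic ring without the ring nitrogen, a straight hexyl chain would add length without a ring, and a carboxylic acid or an amine on the chain remains an open question at this place.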